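A few compounds are considered here, and "the series" means these few. Any claim that something is new, unique, unknown or untested is made for them only; others in the source may bear on it.

The series rests on a shared core, carried by compound 1 `Cc1c(Br)cc(C(=O)NC2CCNCC2)c(=O)n1Cc1ccc(F)cc1`, compound 2 `Cc1ccc(C(=O)NC2CCCCCC2)c(=O)n1Cc1ccc(F)cc1` and compound 3 `Cc1c(-c2ccccc2)cc(C(=O)NC2CCCCCC2)c(=O)n1Cc1ccc(F)cc1`. In an assay on HEK293 cells for inhibition of Lysophosphatidylserine lipase ABHD12 (Homo sapiens), read by scintillation counting, with stated times of 30 min and 5 min (a higher number here means a weaker inhibitor, a lower number a stronger inhibitor), compound 1 gives > 10000 nM, which is a limit of the assay and not a number. Compound 2 likewise reaches only a limit in this assay, > 10000 nM. Compound 3 also stands at a limit in this assay, > 10000 nM. Compound 3 therefore cannot be ranked against the others on the numbers shown; all three sit together at the same limit, (the limit of > 10000 nM in this assay, at which 3 of the 3 values shown sit). For the measured compounds named here, the one step between measured compounds that differ in a single place, a step that the two limits leave unreadable from compound 2 to compound 3, is hidden by the two limits, so its size cannot be read.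

Compound 4 `Cc1c(F)cc(C(=O)NC2CCCCCC2)c(=O)n1Cc1ccc(F)cc1` differs from compound 3 in one place: fluoro in place of phenyl on an aromatic carbon. Going by the values given here, no measured step bears directly on this change, and the only step touching the same place, a step that the two limits leave unreadable from compound 2 to compound 3, is unreadable. With every value shown being a limit, there is no ground to expect compound 4 to move beyond the scatter in this assay, and the most likely outcome is a further limit. Compound 4 is therefore expected to give about 20000 nM, within 5000 nM to 100000 nM. The step that this estimate implies is expected to be a step that the limit leaves unreadable from compound 3 to compound 4.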

Compound 4, half-maximal inhibitory concentration: > 10000 nM
Compound 4 was reported as a limit; the forecaster's own chance of this, stated with the estimate: 85%; the middle value is on the limit's open side.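

In this assay compound 4 gives > 10000 nM, which is a limit of the assay and not a number. For the compounds shown here, no step to compound 4 from compound 2 or compound 3 can be read, and all four compounds stand together: the limit of > 10000 nM in this assay, at which 4 of the 4 values shown sit. The compounds shown leave open whether any change to the shared core would give a measurable value in this assay.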